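This account rests on a few compounds, and the source may have more. Where it says the series, first, only, none or still open, it means among the compounds named here.

Measured so far in a functional assay on H184B5F5/M10 cells (Homo sapiens) for antiproliferative activity, read by MTT assay, with a stated time of 24 h; on this read-out higher numbers stand for weaker inhibition and lower numbers for stronger inhibition:

compound 1, `COc1ccc(C(=O)NNC(=O)/C=C/c2ccc(O)c(O)c2)cc1`: 9570 nM
compound 2, `O=C(/C=C/c1ccc(O)c(O)c1)NNC(=O)c1ccc(O)cc1`: 8680 nM
compound 3, `COc1ccc(C(=O)NNC(=O)/C=C/c2cc(OC)c(O)c(OC)c2)cc1`: 9450 nM

Compound 2 differs from compound 1 by hydrogen in place of methyl on an oxygen on an aromatic ring, and this change gave a 1.1-fold lower number from compound 1 to compound 2 (0.04 log units; within the scatter). Compound 4, `COc1cc(/C=C/C(=O)NNC(=O)c2ccc(O)cc2)cc(OC)c1O`, is not yet measured; it differs from compound 3 by hydrogen in place of methyl on an oxygen on an aromatic ring, the same change on the same kind of place. Compound 3 carries a different core from compound 1, and the difference between the two cores is not broken down here. In this assay the three measured compounds sit close together, all within the usual scatter of one another.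

Since the step from compound 1 to compound 2 stayed within the scatter, compound 4 is expected to sit near compound 3, with an estimated step of a 1.1-fold lower number from compound 3 to compound 4 (0.03 log units; within the scatter). The estimate for compound 4 in this assay is 8800 nM, spanning roughly 5500 nM to 14000 nM.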

Compound 4, half-maximal inhibitory concentration: > 10000 nM
Compound 4 was reported as a limit; the forecaster's own chance of this, stated with the estimate: 5%; middle value at least 1.1-fold (0.05 log units) away from the limit.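

In this assay compound 4 is reported only as a limit, > 10000 nM, not as an exact number. On the core of compound 3, hydrogen in place of methyl on the oxygen gives an at least 1.0-fold higher number from compound 3 to compound 4 (0.02 log units; that floor lies within the scatter), and this figure is only a floor, so the real step could be larger. The change therefore shows no clear difference between the two cores, but this does not prove that they respond alike: the same change on two cores in this assay, a 1.1-fold lower number (0.04 log units; within the scatter) from compound 1 to compound 2 and an at least 1.0-fold higher number (0.02 log units; that floor lies within the scatter) from compound 3 to compound 4; the limit leaves it open whether they differ

The compounds shown leave open how a longer chain on that oxygen, or an amine in its place, would read in this assay. On these data alone, the true value of compound 4 also remains open.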